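This account rests on a few compounds, and the source may have more. Where it says the series, first, only, none or still open, it means among the compounds named here.

Measured compounds:
compound 1, `CCCCCCCCCCCCC/C=C/[C@@H](O)[C@H](COC(=O)CCCN(C)C)NC(=O)C(C)(C)C`, 31000 nM
compound 2, `CCCCCCCCCCCCC/C=C/[C@@H](O)[C@H](COC(=O)NCCN(C)C)NC(=O)C(C)(C)C`, 4100 nM

In an assay on membranes from brain for inhibition of sphingomyelin phosphodiesterase 2 (Rattus norvegicus), using microsomes (on this read-out higher numbers stand for weaker inhibition and lower numbers for stronger inhibition), compound 2 holds the lowest of the two numbers recorded so far; its nearest neighbour is compound 1, and the step of a 7.6-fold lower number from compound 1 to compound 2 (0.88 log units; beyond the scatter) lies beyond the scatter. That step, however, changes two things at once, the ester giving way to a carbamate and the chain shortening by one carbon, so it does not isolate either change.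

Compound 3, `CCCCCCCCCCCCC/C=C/[C@@H](O)[C@H](COC(=O)NCCCN(C)C)NC(=O)C(C)(C)C`, differs from compound 2 only in chain length: (dimethylamino)methyl in place of dimethylamino on a saturated chain carbon, two bonds along the chain from an amide-type nitrogen. For the measured compounds named here, no measured pair shows this change alone. Compound 1 carries the same three-carbon spacer as compound 3 but on an ester, so its value bears on compound 3 only loosely. With the carbamate kept and the spacer lengthened by a single methylene, the expectation is a small step, not clearly in either direction, most likely within the scatter. Compound 3 is therefore expected to give about 6000 nM, between 2000 nM and 20000 nM, an estimated step of a 1.5-fold higher number from compound 2 to compound 3 (0.17 log units; within the scatter).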

Compound 3, half-maximal inhibitory concentration: 4900 nM
Compound 3: the middle estimate sits 1.2-fold (0.09 log units) above what was measured; low and high end bracket the measured number.
By their numbers in this assay, from the lowest: compounds 2 and 3 (each within the scatter of the next); then compound 1.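

In this assay, (dimethylamino)methyl in place of dimethylamino on a saturated chain carbon, two bonds along the chain from an amide-type nitrogen, gives a 1.2-fold higher number from compound 2 to compound 3 (0.08 log units; within the scatter), so compound 2 and compound 3 cannot be separated on the carbamate series and this position tolerates the added methylene here. The pair sharing the longer spacer now isolates the other part of the earlier double change: (3-(dimethylamino)propyl)amino in place of 3-(dimethylamino)propyl on a carbonyl carbon gives a 6.3-fold lower number from compound 1 to compound 3 (0.80 log units; beyond the scatter), a step beyond the scatter that ties the gain to the carbamate in place of the ester, with the chain held constant. Nothing available explains why the carbamate and the ester differ in this way.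

As far as these compounds go, whether the flat response to chain length continues with a longer chain, such as a 4-(dimethylamino)butyl group on the carbamate nitrogen, remains open. Also open, from the compounds shown here alone, are the effects of a urea in place of the carbamate oxygen, of a methyl group in place of the carbamate hydrogen, and of a primary amine in place of the dimethylamino group.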